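Swapping the aryl on the triazole nitrogen: compound 4

A few compounds are considered here, and "the series" means these few. Any claim that something is new, unique, unknown or untested is made for them only; others in the source may bear on it.

Of the compounds shown here, three sharing one core have been tested in a functional assay on PC-12 cells (Rattus norvegicus) for cytotoxicity, read by MTT assay, with stated times of 2 h and 24 h, tested at 5 uM; on this read-out lower numbers stand for a weaker effect and higher numbers for a stronger effect at the one concentration tested. Compound 2 `Oc1cc(C(F)(F)F)ccc1-c1nc(-c2ccccc2O)n(-c2ccc(C(F)(F)F)cc2)n1` gives 90.5%, the highest of the three numbers; compound 1 `Oc1cc(C(F)(F)F)ccc1-c1nc(-c2ccccc2O)n(-c2ccc(Br)cc2)n1` gives 89.8%, within the scatter of compound 2, while compound 3 `Oc1cc(C(F)(F)F)ccc1-c1nc(-c2ccccc2O)n(-c2ccccc2C(F)(F)F)n1` gives 80%, the furthest away. The step of a number 10.5 percentage points lower from compound 2 to compound 3 (beyond the scatter) is the only one beyond the scatter; the step of a number 0.7 percentage points higher from compound 1 to compound 2 (within the scatter) is not.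

Compound 4 `Oc1cc(C(F)(F)F)ccc1-c1nc(-c2ccccc2O)n(-c2ccc(F)cc2F)n1` is not yet measured. It differs from compound 2 in one place: 2,4-difluorophenyl in place of 4-(trifluoromethyl)phenyl on an aromatic nitrogen. The change keeps a group at the 4-position of the phenyl, as in compound 2, and adds one at the 2-position, as in compound 3. The step of a number 10.5 percentage points lower from compound 2 to compound 3 (beyond the scatter) suggests that a 2-substituent may lower the number modestly, and the step of a number 0.7 percentage points higher from compound 1 to compound 2 (within the scatter) suggests that exchanging one small halogen-type group for another at the 4-position matters little. Compound 4 is therefore expected to show a number 5.5 percentage points lower from compound 2 to compound 4 (within the scatter), a step of small size downward, or none beyond the scatter. The estimated value for compound 4 is 85%, in a range from 72% to 95%.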

Compound 4, a percentage reported as activity, at one concentration (the size of the read-out at that concentration, not a potency): 83.5%
Estimate against measurement, compound 4: 1.5 percentage points above; the measured number falls inside the stated range.
By their numbers in this assay, from the lowest: compounds 3, 4, 1 and 2 (each within the scatter of the next, the first and the last beyond it).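

In this assay, 2,4-difluorophenyl on the aromatic nitrogen stays within the scatter of all three other aryl groups shown there (a number 7 percentage points lower from compound 2 to compound 4 (within the scatter); a number 6.3 percentage points lower from compound 1 to compound 4 (within the scatter); a number 3.5 percentage points higher from compound 3 to compound 4 (within the scatter)). Compound 4 therefore carries fluorine in place of the trifluoromethyl of compound 2 and of compound 3 without separating from either, so the step from compound 2 to compound 3 remains the only one beyond the scatter. Nothing available explains why these numbers fall as they do.

Every aryl group shown on this nitrogen is a phenyl bearing only halogen or trifluoromethyl, so the effect of an amine or a carboxylic acid on that phenyl remains open. With a single concentration tested, the read-out also leaves open how the potencies of these compounds compare.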